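The source may hold more compounds than are shown below. What is called first, only, known or untested is meant among the compounds shown, and "the series" means these compounds.

Measured in a functional assay on Gurav cells (Homo sapiens) for inhibition, read by sulforhodamine B assay; a lower number here means a stronger inhibitor of growth, a higher number a weaker inhibitor of growth:

- Compound 1 `Oc1ccc(-c2ccc(-c3ccc(-c4nc5ccccc5[nH]4)cc3)cc2)cc1`: 100000 nM
- Compound 2 `Oc1cccc2[nH]c(-c3ccc(-c4ccc(-c5ccc(OC(F)(F)F)cc5)cc4)cc3)nc12`: 3600 nM

Of these two compounds, compound 2 has the lower number, at 3600 nM, so it is the stronger inhibitor of growth, and its gap to compound 1 lies well beyond the usual scatter of repeat measurements. The next compound to be tested is compound 3 `Oc1ccc(-c2ccc(-c3ccc(-c4nc5c(O)cccc5[nH]4)cc3)cc2)cc1`. Set against compound 2, its structural change is hydrogen in place of trifluoromethyl on an oxygen on an aromatic ring. In words, hydrogen takes the place of trifluoromethyl on an oxygen on an aromatic ring, which turns trifluoromethoxy into hydroxy and 4-(trifluoromethoxy)phenyl into 4-hydroxyphenyl.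

For the measured compounds named here, no measured pair shows this change on its own, so any forecast is uncertain. One clue is that the 4-hydroxyphenyl group is also carried by compound 1, which gives 100000 nM. A move towards weaker growth inhibition is therefore expected, and the expected step is a 4.2-fold higher number from compound 2 to compound 3 (0.62 log units; beyond the scatter). For compound 3 the estimated value in this assay is 15000 nM, with an expected range of 4000 nM to 80000 nM.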

Compound 3, concentration for 50% growth inhibition: 190 nM
Beside the measured number, compound 3's estimate is 79-fold (1.90 log units) above it; measured number outside the range, below it.
By their numbers in this assay, from the lowest: compound 3; then compound 2; then compound 1.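

In this assay, the change from 4-(trifluoromethoxy)phenyl to 4-hydroxyphenyl gives a 19-fold lower number from compound 2 to compound 3 (1.28 log units; beyond the scatter) and so, with the rest of the molecule held constant, the free hydroxy is clearly preferred over trifluoromethoxy at this position. Compound 3 also carries a second hydroxy, and placing this hydroxy in place of hydrogen on an aromatic carbon gives a 530-fold lower number from compound 1 to compound 3 (2.72 log units; beyond the scatter) and shows that a compound with the 4-hydroxyphenyl group can be either very weak or the strongest inhibitor of growth among these three, depending on this one change elsewhere in the molecule. Nothing measured here explains why either change has so large an effect.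

The compounds shown leave open how much the second hydroxy adds when the molecule carries trifluoromethoxy instead of 4-hydroxyphenyl, as its step is seen only in the pair that has 4-hydroxyphenyl. They also leave open whether the hydrogen on the oxygen matters in itself, and whether a methoxy, an amine or a carboxylic acid in place of the hydroxy of the 4-hydroxyphenyl group would keep the growth inhibition of compound 3.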